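The source may hold more compounds than are shown below. What is called first, only, known or untested is meant among the compounds shown, and "the series" means these compounds.

Measured so far:
Compound 1, `CN(C)CCn1cnnc1-c1cc(Oc2ccc(NC(=O)N/N=C/c3ccc(F)cc3)cc2F)ccn1`: in a functional assay on U-87MG ATCC cells (Homo sapiens) for cytotoxicity, read by MTT assay, with a stated time of 72 h (on this read-out higher numbers stand for weaker inhibition and lower numbers for stronger inhibition), compound 1 gives 2310 nM.
Compound 2, `CN(C)CCn1cnnc1-c1cc(Oc2ccc(NC(=O)N/N=C/c3cc(Br)c(O)c(Br)c3)cc2F)ccn1`: in this assay compound 2 gives > 100000 nM, which is a limit of the assay and not a number.

Compound 2 therefore stands at the limit of > 100000 nM in this assay, at which 1 of the 2 values shown sits, the weakest reading the assay reports. For the measured compounds named here, the single measured step, an at least 43-fold higher number from compound 1 to compound 2 (1.63 log units; beyond the scatter), is the one that bears on the change considered here, and it is large. The change from compound 2 to compound 3 is 4-hydroxy-3,5-dimethylphenyl in place of 3,5-dibromo-4-hydroxyphenyl on a carbon with a double bond to nitrogen, giving compound 3, `Cc1cc(/C=N/NC(=O)Nc2ccc(Oc3ccnc(-c4nncn4CCN(C)C)c3)c(F)c2)cc(C)c1O`. Compound 3 keeps the hydroxy group of compound 2 and swaps only the two bromines for two methyls, so compound 3 is expected to move back from the limit of compound 2 by an at least 3.3-fold lower number from compound 2 to compound 3 (0.52 log units; beyond the scatter), a moderate step toward stronger inhibition, though the limit value of compound 2 makes the starting point uncertain. Compound 3 is thus estimated at 30000 nM, with a range from 6000 nM to 100000 nM.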

Compound 3, half-maximal inhibitory concentration: 7710 nM
For compound 3 the middle estimate is 3.9-fold (0.59 log units) above the measured one; the measured number falls inside the stated range.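

At this place, on a carbon with a double bond to nitrogen, the hydroxy group stays and only the two bromines become two methyls, yet this assay shows an at least 12-fold lower number from compound 2 to compound 3 (1.11 log units; beyond the scatter). Even so, the 4-hydroxy-3,5-dimethylphenyl group does not match the 4-fluorophenyl group, with a 3.3-fold higher number from compound 1 to compound 3 (0.52 log units; beyond the scatter), so among these three compounds, compound 1 remains the strongest inhibitor. The reading for compound 2 is a limit of the assay and not a number: the limit of > 100000 nM in this assay, at which 1 of the 3 values shown sits.

As far as these compounds go, it remains open whether the hydroxy group, the methyls or the loss of the fluorine accounts for the gap between the 4-fluorophenyl and 4-hydroxy-3,5-dimethylphenyl groups. A 3,5-dimethylphenyl group without the hydroxy, or a 4-aminophenyl group, would help to separate these parts of the change.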